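Swapping the aryl group on a cinnamamide quinazoline

The source may hold more compounds than are shown below. What is called first, only, known or untested is meant among the compounds shown, and "the series" means these compounds.

Measured compounds:
compound 1, `O=C(/C=C/c1cccc(Cl)c1Cl)Nc1cc2c(Nc3ccc(F)c(Cl)c3)ncnc2cc1O[C@H]1CCOC1`: 23200 nM
compound 2, `COc1ccc(/C=C/C(=O)Nc2cc3c(Nc4ccc(F)c(Cl)c4)ncnc3cc2OC)cc1`: "not active" (no number reported)
compound 3, `N#Cc1ccc(/C=C/C(=O)Nc2cc3c(Nc4ccc(F)c(Cl)c4)ncnc3cc2O[C@H]2CCOC2)cc1`: "not active" (no number reported)

Of the compounds shown here, three sharing one core have been tested in a functional assay on A549 cells (Homo sapiens) for cytotoxicity, read by MTT assay, with a stated time of 72 h; on this read-out higher numbers stand for weaker inhibition and lower numbers for stronger inhibition. For the measured compounds named here, compound 1 is the only one with a number: in this assay compound 1 gives 23200 nM. For compound 2 this assay reports only "not active" (no number reported), with no number. For compound 3 this assay likewise reports "not active" (no number reported), again with no number. Going by the values given here, compound 1 therefore stands alone as the single measured value, and nothing can be said about how far the other two lie from it.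

Compound 4, `O=C(/C=C/c1ccc(Br)cc1)Nc1cc2c(Nc3ccc(F)c(Cl)c3)ncnc2cc1O[C@H]1CCOC1`, has not yet been measured. It differs from compound 1 in one place: 4-bromophenyl in place of 2,3-dichlorophenyl on a double-bonded chain carbon bound to a double-bonded chain carbon. Compound 2 and compound 3 each carry a phenyl bearing a single group, and neither gave a number; compound 1, which does give a number, carries two chlorines. On that slim basis a loss rather than a gain is expected for compound 4, though the change could also fall within scatter.

The step from compound 1 to compound 4 is expected to be a 1.5-fold higher number from compound 1 to compound 4 (0.18 log units; within the scatter). Compound 4 is estimated at 35000 nM, within a range from 12000 nM to 100000 nM.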

Compound 4, half-maximal inhibitory concentration: 35300 nM
The estimate for compound 4 lay 1.0-fold (0.00 log units) below the measured number; low and high end bracket the measured number.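

In this assay, replacing 2,3-dichlorophenyl with 4-bromophenyl on a double-bonded chain carbon bound to a double-bonded chain carbon gives a 1.5-fold higher number from compound 1 to compound 4 (0.18 log units; within the scatter), so this position accepts both of these halogen-bearing phenyl groups with no difference that can be told from scatter. Compound 4 also shows that a phenyl with a single group can give a number here, whereas compound 3, which differs from compound 4 only in having a nitrile where compound 4 has bromine, has none, so steps involving compound 3 or compound 2 cannot be read. No supporting measurement bears on why the two halogen-bearing phenyl groups read alike or why the nitrile-bearing compound has no number.

The compounds shown leave open how much of the reading depends on the halogens themselves, since an unsubstituted phenyl, or one carrying only fluorine, would be needed to test that. They also leave open whether an amine or a carboxylic acid on the phenyl, or a longer chain between that ring and the carbonyl, would move the number beyond the scatter.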